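A few compounds are considered here, and "the series" means these few. Any claim that something is new, unique, unknown or untested is made for them only; others in the source may bear on it.

Measured compounds:
compound 1 `CC(C)/C=C/C(=O)Nc1cc2c(N3CCc4ccccc43)ncnc2cc1O[C@@H]1CCOC1` gives 8520 nM in a functional assay on A549 cells (Homo sapiens) for antiproliferative activity, read by MTT assay, with a stated time of 72 h; on this read-out higher numbers stand for weaker inhibition and lower numbers for stronger inhibition
compound 2 `CC/C=C/C(=O)Nc1cc2c(N3CCCc4ccccc43)ncnc2cc1OC` gives 5030 nM in this assay
compound 3 `CC/C=C/C(=O)Nc1cc2c(N3CCCc4ccccc43)ncnc2cc1O[C@@H]1CCOC1` gives 14100 nM in this assay

Compound 2 stands lowest of the three numbers in this assay. Its nearest neighbour is compound 1, whose number lies within the scatter of that of compound 2, so no order between the two can be read. Going by the values given here, the only step beyond the scatter is a 2.8-fold higher number from compound 2 to compound 3 (0.45 log units; beyond the scatter), where the change sits on the oxygen on the aromatic ring.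

The next compound, compound 4 `COc1cc2ncnc(N3CCCc4ccccc43)c2cc1NC(=O)/C=C/CN1CCCC1`, is not yet measured. It differs from compound 2 by pyrrolidin-1-yl in place of methyl on a saturated chain carbon bound to a double-bonded chain carbon. Among the compounds with values here, no measured step touches this place: the one step beyond the scatter, a 2.8-fold higher number from compound 2 to compound 3 (0.45 log units; beyond the scatter), concerns the oxygen on the aromatic ring, and the pair of compound 1 and compound 3 differs at two places at once and yields no single step. The expectation for compound 4 therefore rests on compound 2 alone, with no directional evidence, and the number for compound 4 is expected to sit within a wide band around that of compound 2, a step of a 1.4-fold lower number from compound 2 to compound 4 (0.16 log units; within the scatter) being the estimate. Compound 4 is estimated at 3500 nM, with a range from 900 nM to 14000 nM.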

Compound 4, half-maximal inhibitory concentration: 2230 nM
Beside the measured number, compound 4's estimate is 1.6-fold (0.20 log units) above it; low and high end bracket the measured number.
By their numbers in this assay, from the lowest: compound 4; then compounds 2, 1 and 3 (each within the scatter of the next, the first and the last beyond it).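

In this assay, the far end of the but-1-en-1-yl chain on the amide carbonyl proves to be a place where a single change moves the number beyond the scatter: a 2.3-fold lower number from compound 2 to compound 4 (0.35 log units; beyond the scatter). This step runs opposite to the only earlier single change, a 2.8-fold higher number from compound 2 to compound 3 (0.45 log units; beyond the scatter), which sits on the oxygen on the aromatic ring, so the two places shown respond in different directions; with one step at each place, this is no trend for either. At the chain end, a methyl of one heavy atom gives way to a pyrrolidin-1-yl of five heavy atoms, which carries one hydrogen-bond acceptor and a five-membered ring, and the number still goes down, but no measurement at hand explains the shift.

Going by these compounds, with one group at this place, it remains open whether the ring, the nitrogen or the added size goes with the lower number, and a dimethylamino group, a piperidin-1-yl or a morpholin-4-yl at the same carbon would separate these readings. Also open, on these data alone, is how pyrrolidin-1-yl at this place behaves with oxolan-3-yl in place of methyl on the aromatic oxygen, as in compound 3.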